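This account rests on a few compounds, and the source may have more. Where it says the series, first, only, none or still open, it means among the compounds named here.

Measured compounds:
- compound 1, `O=C(CSc1nncnc1-c1ccccc1Cl)c1ccc(Cl)c(Cl)c1`: 33000 nM
- compound 2, `O=C(CSc1nncnc1-c1cccc2ccccc12)Nc1ccccc1`: 154000 nM
- compound 3, `O=C(CSc1nncnc1-c1cccc2ccccc12)Nc1ccccc1Br`: 87000 nM

In an ADME assay on MT4 cells (Homo sapiens) for cytotoxicity, read by MTT assay (on this read-out higher numbers stand for lower toxicity in this test and lower numbers for higher toxicity in this test), compound 1 gives the lowest number of the three, and its distance to both compound 3 and compound 2 lies beyond the scatter, so it is the most toxic of the measured set in this test. Compound 4, `O=C(CSc1nncnc1-c1ccccc1Cl)Nc1ccccn1`, is not yet measured. It differs from compound 1 in one place: (pyridin-2-yl)amino in place of 3,4-dichlorophenyl on a carbonyl carbon. Among the measured compounds shown here, the only measured step, a 1.8-fold lower number from compound 2 to compound 3 (0.25 log units; within the scatter), concerns a small change on the aromatic ring attached to the amide and does not speak to swapping an aryl ketone for an amide. Compounds 2 and 3 are amides and both give higher numbers than compound 1, but they also carry a different aromatic group on the shared core, so that comparison is not clean. Compound 4 is therefore expected to give a somewhat higher number, a 1.8-fold higher number from compound 1 to compound 4 (0.26 log units; within the scatter), with wide uncertainty. The estimate for compound 4 is 60000 nM, in the range 20000 nM to 180000 nM.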

Compound 4, half-maximal cytotoxic concentration: 172000 nM
The estimate for compound 4 lay 2.9-fold (0.46 log units) below the measured number; the measured number falls inside the stated range.
By their numbers in this assay, from the lowest: compound 1; then compounds 3, 2 and 4 (each within the scatter of the next).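

In this assay, the exchange of 3,4-dichlorophenyl for (pyridin-2-yl)amino on the carbonyl carbon gives a 5.2-fold higher number from compound 1 to compound 4 (0.72 log units; beyond the scatter), which is beyond the scatter and points to lower toxicity in this test. This is the only comparison shown at this position with the rest of the molecule unchanged, so it shows that this position alone can shift the number beyond the scatter. The exchange alters several things at once, turning a ketone into an amide, bringing a nitrogen into the ring and removing both chlorines, and no measurement here explains the shift.

It remains open which of these alterations accounts for the step. Also open, going by these compounds, is how a saturated amine such as morpholine, or a carboxylic acid, would behave on the same carbonyl carbon.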